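Oxazole for fluoropyridine on the shared core

A few compounds are considered here, and "the series" means these few. Any claim that something is new, unique, unknown or untested is made for them only; others in the source may bear on it.

Compound 1 `O=S(=O)(Nc1nccs1)c1ccc2c(c1)OCC[C@H]2c1ccc(C(F)(F)F)cc1-c1ccc(F)nc1` carries a 6-fluoropyridin-3-yl group on the aryl ring that bears the trifluoromethyl group, with the sulfonamide on a thiazole. In a physicochemical assay for lipophilicity (a higher number here means a more lipophilic compound, a lower number a more polar compound), compound 1 gives "not determined" (no result reported); no result was reported for it, so it stands without a value and nothing can be said of its own position.

Two neighbours in the series do have values. Compound 2 `Cn1nccc1-c1cc(C(F)(F)F)ccc1[C@H]1CCOc2cc(S(=O)(=O)Nc3cccc(F)n3)ccc21` in this assay gives 3.6. Compound 3 `Cc1ccc(-c2cc(C(F)(F)F)ccc2[C@H]2CCc3cc(S(=O)(=O)Nc4ncccn4)ccc32)cn1` in this assay gives 2.8. Among the measured compounds shown here, these two differ from each other and from compound 1 in more than one place, so their values are noted only as the span covered by the series so far, not as a step.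

Compound 4 `Cc1nc(-c2cc(C(F)(F)F)ccc2[C@@H]2CCOc3cc(S(=O)(=O)Nc4nccs4)ccc32)co1` keeps the core of compound 1 and the thiazole sulfonamide. The change from compound 1 is 2-methyl-1,3-oxazol-4-yl in place of 6-fluoropyridin-3-yl on an aromatic carbon. For the measured compounds named here, no measured pair shows this exact change. The step in this assay is expected to be small and, if anything, downward, probably not far beyond the scatter of the measurement. Since compound 1 has no number, the expectation rests on where compound 2 and compound 3 fall. The value of compound 4 in this assay is estimated at 3.2, with a range from 2.6 to 3.8.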

Compound 4, distribution coefficient: 2.9
For compound 4 the middle estimate is 0.30 log units above the measured one, within the range that was stated.
By their numbers in this assay, from the lowest: compounds 3 and 4 (each within the scatter of the next); then compound 2.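

No new step can be read for compound 4 in this assay: compound 1 has no single number, and compound 2 and compound 3 differ from it in more than one place. The compounds shown leave open how 2-methyl-1,3-oxazol-4-yl in place of 6-fluoropyridin-3-yl moves the value on the shared core. No supporting evidence bears on this result.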